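A few compounds are considered here, and "the series" means these few. Any claim that something is new, unique, unknown or untested is made for them only; others in the source may bear on it.

Compound 1 `Cc1cccc(NC(=O)Nc2ccc(Oc3ncnc4[nH]ncc34)cc2)c1C`: 98800 nM in an assay on isolated protein for inhibition of vascular endothelial growth factor receptor 2 (Danio rerio), read by fluorescence and microscopy, with a stated time of 33 h; a higher number here means a weaker inhibitor, a lower number a stronger inhibitor.
Compound 2 `O=C(Nc1ccc(Oc2ncnc3[nH]ncc23)cc1)NC1CCCCC1`: > 100000 nM, a limit of the assay rather than a number.
Compound 3 `O=C(NCC1CCCCC1)Nc1ccc(Oc2ncnc3[nH]ncc23)cc1`: > 100000 nM, again a limit of the assay rather than a number.

Compound 3 therefore stands at the upper edge of what this assay can report, and it shares that position with one other compound, since (the limit of > 100000 nM in this assay, at which 2 of the 3 values shown sit). Only compound 1 gives an actual number, and that number lies close to the same limit. Compound 4 `CC(C)c1cccc(NC(=O)Nc2ccc(Oc3ncnc4[nH]ncc34)cc2)c1` differs from compound 3 by 3-isopropylphenyl in place of cyclohexylmethyl on an amide-type nitrogen. The most relevant measured step runs the other way, from an aromatic ring to cyclohexylmethyl: an at least 1.0-fold higher number from compound 1 to compound 3 (0.00 log units; that floor lies within the scatter). The step that the two limits leave unreadable from compound 2 to compound 3 gives no readable size. Putting an aromatic ring back in the place of cyclohexylmethyl is thus expected to change little. Compound 4 is expected to give about 100000 nM, between 30000 nM and 300000 nM, and most likely to be reported only as a limit again. Compound 4 is accordingly expected to show a number no higher from compound 3 to compound 4 (the limit leaves the size open).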

Compound 4, half-maximal inhibitory concentration: 7730 nM
Estimate against measurement, compound 4: 13-fold (1.11 log units) above; measured number below the stated range.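

In this assay, this place on the amide-type nitrogen proves able to move the number well clear of the limit: 3-isopropylphenyl gives an at least 12-fold lower number from compound 3 to compound 4 (1.11 log units; beyond the scatter) and an at least 12-fold lower number from compound 2 to compound 4 (1.11 log units; beyond the scatter). An aromatic ring alone does not account for this, as compound 1 also carries one and stays close to the limit, while the change to 3-isopropylphenyl gives a 13-fold lower number from compound 1 to compound 4 (1.11 log units; beyond the scatter); what is attached to the ring therefore matters as well. The steps from compound 2 and compound 3 start from limits rather than numbers, so their sizes are only floors: the limit of > 100000 nM in this assay, at which 2 of the 4 values shown sit.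

Going by these compounds, it remains open what plain phenyl would give on the same nitrogen, and so how much of the result belongs to the isopropyl group itself. On these data alone, compound 4 gives 7730 nM; also open is whether a larger group such as 3-tert-butylphenyl or a 3-methoxyphenyl ring would give a still lower number.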